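Anilino aryl swap on the shared core

The compounds below may be only part of what the source reports. "The series", "measured", "known", "first", "only" and "open" are said of these compounds alone.

Compound 1 `Cc1cccc(Nc2nc(C)c(C(=O)/C=C/c3ccc(Cl)cc3)s2)c1` is the point of departure. In a functional assay on PC-3 cells (Homo sapiens) for cytotoxicity, read by MTT assay (on this read-out lower numbers stand for stronger inhibition and higher numbers for weaker inhibition), compound 1 gives only a limit, > 25000 nM; its position is thus known only as a limit (the limit of > 25000 nM in this assay, at which 1 of the 3 values shown sits). Compound 2 `Cc1cccc(Nc2nc(C)c(C(=O)/C=C/c3ccccc3Cl)s2)c1` gives 22200 nM in this assay, and compound 3 `Cc1cccc(Nc2nc(C)c(C(=O)/C=C/c3ccccc3)s2)c1` gives 11700 nM. All measured steps change the aryl on the double-bonded chain carbon: an at least 1.1-fold lower number from compound 1 to compound 2 (0.05 log units; that floor lies within the scatter); an at least 2.1-fold lower number from compound 1 to compound 3 (0.32 log units; beyond the scatter); a 1.9-fold lower number from compound 2 to compound 3 (0.28 log units; within the scatter). Compound 4 `Cc1nc(Nc2ccc(Cl)cc2)sc1C(=O)/C=C/c1ccc(Cl)cc1` keeps the 4-chlorophenyl of compound 1 on the chain and alters the other end: 4-chlorophenyl in place of 3-methylphenyl on a nitrogen on an aromatic ring. Within the data shown here, no measured step touches the nitrogen on the aromatic ring, so none bears directly on this change; the three measured values show only that the series as a whole sits at the weak end of this assay. Among the measured compounds shown here, with no guiding step, the expectation in this assay is no step beyond the scatter, a step that the limit leaves unreadable from compound 1 to compound 4. Compound 4 is therefore estimated at 30000 nM in this assay, between 10000 nM and 100000 nM, with a fair chance that again only a limit is reported.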

Compound 4, half-maximal inhibitory concentration: > 25000 nM
Compound 4: only a limit was reported (the forecaster's own chance of this, stated with the estimate: 60%); the middle value does not contradict the limit.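

Among these compounds, compound 1 and compound 4 both rest at a limit rather than a number, so no step between them can be read: the limit of > 25000 nM in this assay, at which 2 of the 4 values shown sit.

The compounds shown leave open whether (4-chlorophenyl)amino in place of (3-methylphenyl)amino changes the read-out in this assay at all.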